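Sec-Butyl to Isobutyl: One Step Made Twice

The compounds below may be only part of what the source reports. "The series", "measured", "known", "first", "only" and "open" are said of these compounds alone.

Compound 1 `Cc1nc2ccccc2nc1Oc1ccc(C(=O)N[C@@H](CC(C)C)C(=O)O)cc1`: 19500 nM
Compound 2 `CC[C@@H](C)[C@H](NC(=O)c1ccc(Oc2nc3ccccc3nc2C)cc1)C(=O)O`: 30500 nM
Compound 3 `CC[C@@H](C)[C@H](NC(=O)c1ccc(Oc2nc3ccccc3nc2NC(C)(C)C)cc1)C(=O)OC`: 38700 nM

Of the compounds shown here, three have been measured in a functional assay on K562 cells (Homo sapiens) for antiproliferative activity, read by MTT assay, with a stated time of 48 h; on this read-out higher numbers stand for weaker inhibition and lower numbers for stronger inhibition. Compound 2 differs from compound 1 only by isobutyl in place of sec-butyl on a saturated chain carbon bound to an amide-type nitrogen and a carbonyl carbon, and this gave a 1.6-fold lower number from compound 2 to compound 1 (0.19 log units; within the scatter). Compound 3 stands furthest from the others, but its gaps to compound 2 and to compound 1 are both within the scatter, so no order among the three can be drawn. How the core of compound 3 differs from that of compound 2 is not broken down here.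

Compound 4 `COC(=O)[C@H](CC(C)C)NC(=O)c1ccc(Oc2nc3ccccc3nc2NC(C)(C)C)cc1` is not yet measured. It differs from compound 3 by isobutyl in place of sec-butyl on a saturated chain carbon bound to an amide-type nitrogen and a carbonyl carbon. The place is the same in words as for the change from compound 2 to compound 1, so this is the same kind of change made on a different core. Because the earlier step was a 1.6-fold lower number from compound 2 to compound 1 (0.19 log units; within the scatter) and lay within the scatter, a step of similar size is expected here, and the estimate for compound 4 is a 1.6-fold lower number from compound 3 to compound 4 (0.21 log units; within the scatter). With that step, compound 4 is expected to give about 24000 nM in this assay, most likely between 10000 nM and 60000 nM. The rest is the second core, whose own effect on this change is not shown by the measured compounds.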

Compound 4, half-maximal inhibitory concentration: > 50000 nM
Compound 4 gave a limit, no number; the forecaster's own chance of this, stated with the estimate: 10%; middle value at least 2.0-fold (0.31 log units) from the limit.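

In this assay compound 4 gave > 50000 nM, which is a limit of the assay and not a number. Read against compound 3, isobutyl in place of sec-butyl gives an at least 1.2-fold higher number from compound 3 to compound 4 (0.11 log units; that floor lies within the scatter), so only a floor is known for this step and its true size stays unknown. Set beside the same change on the core of compound 1, the two steps compare as follows: the same change on two cores in this assay, a 1.6-fold lower number (0.19 log units; within the scatter) from compound 2 to compound 1 and an at least 1.2-fold higher number (0.11 log units; that floor lies within the scatter) from compound 3 to compound 4; the limit leaves it open whether they differ This shows only that the one pair of compounds with a full number gives a step within the scatter and that the second pair ends at a limit; it does not show that the change carries from one core to the other, nor that it fails to carry.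

The compounds shown leave open how much of any difference between the two cores belongs to the methyl ester, set against the carboxylic acid, and how much to the tert-butylamino group, set against the methyl group, since these two parts vary together here. Also open, going by these compounds, is how a straight n-butyl chain or a benzyl group would read on a saturated chain carbon bound to an amide-type nitrogen and a carbonyl carbon, on either core.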